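The source may report more compounds than this note shows. Statements on the series, on what has been measured and on what is new or still open speak of the compounds shown alone.

Measured in a functional assay on CAL-27 cells (Homo sapiens) for cytotoxicity, read by MTT assay, with a stated time of 72 h; a lower number here means a stronger inhibitor, a higher number a weaker inhibitor:
Compound 1 `Cc1cc(C)cc(C(=O)N(CCCCCC(=O)Nc2ccccc2N)CC(=O)NC2CCCCC2)c1`: 17500 nM
Compound 2 `Nc1ccccc1NC(=O)CCCCCN(CC(=O)NC1CCCCC1)C(=O)c1cccc2ccccc12`: 24900 nM

Compound 2 stands within the scatter of compound 1, so the two cannot be ranked on these numbers. Compound 3 `Nc1ccccc1NC(=O)CCCCCN(CC(=O)NC1CCCCC1)C(=O)c1ccccc1` carries phenyl in place of naphthalen-1-yl on a carbonyl carbon. Among the compounds with values here, only one measured step bears on this change, and it also exchanges the group on that carbonyl carbon: a 1.4-fold higher number from compound 1 to compound 2 (0.15 log units; within the scatter). In this assay no step beyond the scatter is therefore expected, in either direction. The expected change is a 1.2-fold lower number from compound 2 to compound 3 (0.07 log units; within the scatter). For compound 3 the estimate is 21000 nM, with an expected range from 9000 nM to 48000 nM.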

Compound 3, half-maximal inhibitory concentration: 30900 nM
The estimate for compound 3 lay 1.5-fold (0.17 log units) below the measured number; measured number inside the range.
By their numbers in this assay, from the lowest: compounds 1, 2 and 3 (each within the scatter of the next).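

In this assay, the exchange of naphthalen-1-yl for phenyl on the carbonyl carbon gives a small step (a 1.2-fold higher number from compound 2 to compound 3 (0.09 log units; within the scatter)). The exchange of 3,5-dimethylphenyl for phenyl also stays small (a 1.8-fold higher number from compound 1 to compound 3 (0.25 log units; within the scatter)), so compound 3, with one aromatic ring of carbon only, cannot be separated from either compound with the other groups at this position. Nothing measured here offers a reason for this result. As far as these compounds go, all three groups are carbon-only aromatics, so it remains open whether an amine or carboxylic acid on the phenyl ring, or a pyridine ring in its place, would produce a step beyond the scatter.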